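The compounds below may be only part of what the source reports. "The series", "measured", "known", "first", "only" and "open" are said of these compounds alone.

Compound 1 `O=C(Nc1cc(Sc2ncn[nH]2)c(O)c2ccccc12)c1ccc2ccccc2c1` carries a naphthalen-2-yl on the carbonyl carbon. In a functional assay on PC-3 cells (Homo sapiens) for antiproliferative activity, read by MTT assay, with a stated time of 48 h (on this read-out higher numbers stand for weaker inhibition and lower numbers for stronger inhibition), compound 1 reaches only a limit of the assay, > 100000 nM. Compound 2 `O=C(Nc1cc(Sc2ncn[nH]2)c(O)c2ccccc12)c1ccc(Cl)cc1` has 4-chlorophenyl in that place, and in this assay compound 2 gives 5520 nM. The step of an at least 18-fold lower number from compound 1 to compound 2 (1.25 log units; beyond the scatter) is bounded on one side by the limit of > 100000 nM in this assay, at which 1 of the 2 values shown sits. Compound 2 thus holds the only actual number shown; the other value is a limit. Compound 3 `COc1cccc(C(=O)Nc2cc(Sc3ncn[nH]3)c(O)c3ccccc23)c1` differs from compound 2 by 3-methoxyphenyl in place of 4-chlorophenyl on a carbonyl carbon. Among the measured compounds shown here, the single measured step touches the same carbonyl-bound aryl, yet it removes naphthalen-2-yl altogether, whereas here one substituted phenyl replaces another; it offers little guide beyond showing that this position can move the read-out. The expectation for compound 3 is a step of a 1.4-fold higher number from compound 2 to compound 3 (0.16 log units; within the scatter) that stays near the scatter. Compound 3 is estimated at 8000 nM, within 2500 nM to 30000 nM.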

Compound 3, half-maximal inhibitory concentration: 42100 nM
Compound 3: the middle estimate sits 5.3-fold (0.72 log units) below what was measured; the whole stated range lies below it.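

In this assay, the carbonyl-bound aryl proves sensitive even when one substituted phenyl replaces another, with 3-methoxyphenyl in place of 4-chlorophenyl giving a 7.6-fold higher number from compound 2 to compound 3 (0.88 log units; beyond the scatter). The earlier pair showed only that moving from naphthalen-2-yl to 4-chlorophenyl shifts the read-out, whereas this result separates two single-ring groups at the same place, and compound 2 keeps the lowest actual number shown. Compound 3 still gives a real number, and the comparison with the naphthalen-2-yl compound, an at least 2.3-fold lower number from compound 1 to compound 3 (0.37 log units; beyond the scatter), is only a bound: the limit of > 100000 nM in this assay, at which 1 of the 3 values shown sits.

The compounds shown leave open whether the gap between compound 2 and compound 3 follows the substituent or its location on the phenyl ring, as both differ at once. As far as these compounds go, how 4-methoxyphenyl, 3-chlorophenyl or a phenyl carrying an amine or a carboxylic acid would read here also remains open.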